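Methoxy in place of hydrogen on compound 3

The compounds below may be only part of what the source reports. "The series", "measured", "known", "first", "only" and "open" are said of these compounds alone.

Of the compounds shown here, three sharing one core have been read in an ADME assay on L02 cells (Homo sapiens) for cytotoxicity, read by MTT assay, with a stated time of 24 h; a lower number here means a stronger inhibitor, a higher number a weaker inhibitor. Compound 1 (`COc1cc(/C=C2\CN(C)C/C(=C\c3ccc(Br)cc3)C2=O)cc(OC)c1`) gives 21300 nM, compound 2 (`COc1cc(/C=C2\CN(C)C/C(=C\c3ccc(Cl)cc3Cl)C2=O)cc(OC)c1`) gives 18800 nM and compound 3 (`COc1cc(/C=C2\CN(C)C/C(=C\c3cccc([N+](=O)[O-])c3)C2=O)cc(OC)c1`) gives 10800 nM. These numbers do not separate compound 3 from its neighbours: the steps are a 2.0-fold lower number from compound 1 to compound 3 (0.29 log units; within the scatter) and a 1.7-fold lower number from compound 2 to compound 3 (0.24 log units; within the scatter), alongside a 1.1-fold lower number from compound 1 to compound 2 (0.05 log units; within the scatter).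

Compound 4 (`COc1cc(/C=C2\CN(C)C/C(=C\c3cccc([N+](=O)[O-])c3)C2=O)cc(OC)c1OC`) differs from compound 3 by methoxy in place of hydrogen on an aromatic carbon. The change is methoxy in place of hydrogen on an aromatic carbon, ortho to two methoxy groups and para to a large group.

Among the measured compounds shown here, none of the measured steps touches that aromatic ring. Each one exchanges the substituted phenyl group on a double-bonded chain carbon bound to a double-bonded ring carbon, so they bear on the new change only indirectly. For the measured compounds named here, no measured pair adds or removes a methoxy group, and the data favour no direction. The expectation therefore stays close to compound 3 at 10800 nM, with no shift beyond the scatter in this assay. The estimated step is a 1.0-fold higher number from compound 3 to compound 4 (0.01 log units; within the scatter). Compound 4 is expected at 11000 nM, with an estimated range of 5000 nM to 24000 nM.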

Compound 4, half-maximal inhibitory concentration: 13600 nM
Beside the measured number, compound 4's estimate is 1.2-fold (0.09 log units) below it; low and high end bracket the measured number.
By their numbers in this assay, from the lowest: compounds 3, 4, 2 and 1 (each within the scatter of the next).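

In this assay, methoxy in place of hydrogen on an aromatic carbon, ortho to two methoxy groups and para to a large group, gives a 1.3-fold higher number from compound 3 to compound 4 (0.10 log units; within the scatter), and this is the only step shown that touches this aromatic ring rather than the substituted phenyl group on the double-bonded chain carbon. With the 3-nitrophenyl group held fixed, this position therefore takes a methoxy group without a shift that can be told from the scatter, a reading that rests on this single pair. No measured property accompanies the step, so the series offers no explanation for this result.

On these data alone, whether this position responds differently to a hydroxyl group, an amine or a longer alkoxy chain remains open, as does whether the same methoxy change reads alike with the 4-bromophenyl group of compound 1 or the 2,4-dichlorophenyl group of compound 2. Also open, as far as these compounds go, is whether any change on this ring can produce a step beyond the scatter in this assay.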